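The source may hold more compounds than are shown below. What is called first, only, known or untested is meant among the compounds shown, and "the series" means these compounds.

Measured in an in vitro ADME assay on microsomes from liver (Homo sapiens) for pharmacokinetics; on this read-out higher numbers stand for fast clearance and lower numbers for slow clearance:
Compound 1 `CN1CC[C@H](NC(=O)C[C@@H]2C(=O)NC=CN2S(=O)(=O)c2cccc(Cl)c2Cl)C(C)(C)C1`: 33 mL.min-1.g-1
Compound 2 `Cc1cc(S(=O)(=O)N2C=CNC(=O)[C@H]2CC(=O)N2CC[C@H](N3CCCC3)C2)c(C)cc1Cl`: 265 mL.min-1.g-1

Of these two numbers, the higher belongs to compound 2, at 265 mL.min-1.g-1. Compound 1 lies below it, and the gap is beyond the usual scatter of repeat measurements. Compound 3 `Cc1cc(S(=O)(=O)N2C=CNC(=O)[C@H]2CC(=O)N2CCC3(CCN(C)C3)C2)c(C)cc1Cl` has not yet been measured in this assay. It has the same atoms as compound 2, joined differently: a group of 10 heavy atoms (8 carbon, 2 nitrogen; 2 five-membered non-aromatic rings with 1 hetero atom each) in place of a group of 10 heavy atoms (8 carbon, 2 nitrogen; 2 five-membered non-aromatic rings with 1 hetero atom each), on a carbonyl carbon. The rest of the molecule is unchanged. Within the data shown here, no measured pair of compounds differs in just one place, so the data offer no direct guide to this change. The low number of compound 1, 33 mL.min-1.g-1, cannot be credited to any single part of its structure. The expected change, a 1.6-fold lower number from compound 2 to compound 3 (0.19 log units; within the scatter), is a slight fall that stays within the scatter. For compound 3 the estimated value is 170 mL.min-1.g-1, with an expected range from 70 mL.min-1.g-1 to 400 mL.min-1.g-1.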

Compound 3, intrinsic clearance in microsomes: 28 mL.min-1.g-1
The estimate for compound 3 lay 6.1-fold (0.78 log units) above the measured number; the measured number lies below the stated range.
By their numbers in this assay, from the lowest: compounds 3 and 1 (each within the scatter of the next); then compound 2.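

In this assay, this change on a carbonyl carbon gives a 9.5-fold lower number from compound 2 to compound 3 (0.98 log units; beyond the scatter), so the group at this place has a strong influence on the read-out, even with no atom gained or lost. The two groups share the same printed counts: 10 heavy atoms (8 carbon, 2 nitrogen), 2 five-membered non-aromatic rings with 1 hetero atom each, and 1 hydrogen-bond acceptor, so these counts alone do not predict the result and the way the atoms are joined matters here. Nothing measured here gives a reason for this fall.

Going by these compounds, whether a piperidine or a morpholine in place of the entering group would keep the number as low remains open. Also open, on these data alone, is whether the same exchange would have a similar effect on the core of compound 1.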